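Removing a benzyl group from an inactive compound

The source may report more compounds than this note shows. Statements on the series, on what has been measured and on what is new or still open speak of the compounds shown alone.

Measured in a functional assay on HL-60 cells (Homo sapiens) for cytotoxicity, read by MTT assay, with a stated time of 72 h; a lower number here means a stronger inhibitor, a higher number a weaker inhibitor:
- Compound 1 `C=CC(C)(C/C=C(\C)CCC=C(C)C)c1ccc(OCc2ccccc2)c(OCc2ccccc2)c1`: "not active" (no number reported)
- Compound 2 `C=CC(C)(C/C=C(\C)CCC=C(C)C)c1ccc(OCc2ccccc2)c(O)c1`: "not active" (no number reported)
- Compound 3 `C=CC(C)(C/C=C(\C)CCC=C(C)C)c1ccc(O)c(OC)c1`: 14.4 ug/mL

Not yet measured: compound 4 `C=CC(C)(C/C=C(\C)CCC=C(C)C)c1ccc(OC)c(O)c1`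

Compound 2 has no number to start from. In this assay compound 2 is recorded as "not active" (no number reported), the same result as compound 1 at "not active" (no number reported). The structural step hydrogen in place of phenyl on a saturated chain carbon bound to an oxygen on an aromatic ring puts hydrogen in place of phenyl on a saturated chain carbon bound to an oxygen on an aromatic ring, so benzyloxy becomes methoxy. Going by the values given here, no measured pair shows this change, so the size of the step in this assay cannot be calculated. A move toward stronger inhibition is expected, from no number to a measurable one. Among the compounds with values here, this expectation rests on compound 3 at 14.4 ug/mL, the only number so far. For compound 4 the estimated value is 15 ug/mL, with an expected range of 6 ug/mL to 40 ug/mL.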

Compound 4, half-maximal inhibitory concentration: 18.8 ug/mL
Compound 4: the middle estimate sits 1.3-fold (0.10 log units) below what was measured; the range from low to high includes it.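

Going by these compounds alone, compound 2 has no number in this assay, so no step to compound 4 can be read. The compounds shown leave open how far apart these two lie. No measured evidence explains the difference in their results.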